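From compound 3 to compound 4: the expected step

A few compounds are considered here, and "the series" means these few. Any claim that something is new, unique, unknown or untested is made for them only; others in the source may bear on it.

Measured in an ADME assay on NHDF cells (Homo sapiens) for cytotoxicity, read by MTT assay, with a stated time of 72 h; on this read-out higher numbers stand for weaker inhibition and lower numbers for stronger inhibition:
- compound 1 `COc1cccc(/C=C2\CCC/C(=C\c3cccc(Cl)c3Cl)C2=O)c1OC` gives > 50000 nM as a limit of the assay
- compound 2 `COc1ccc(/C=C2\CCC/C(=C\c3ccc(Cl)cc3)C2=O)cc1OC` gives 11200 nM as a number
- compound 3 `COc1ccc(/C=C2\CCC/C(=C\c3cccc(Br)c3)C2=O)cc1OC` gives 12400 nM as a number

Among the compounds with values here, compound 3 lies within the scatter of compound 2, and these two are the only numerical values so far. Next comes compound 4 `COc1ccc(/C=C2\CCC/C(=C\c3ccc(OC)c(OC)c3)C2=O)cc1`, with 4-methoxyphenyl in place of 3-bromophenyl on a double-bonded chain carbon bound to a double-bonded ring carbon. The change is 4-methoxyphenyl in place of 3-bromophenyl on a double-bonded chain carbon bound to a double-bonded ring carbon. Within the data shown here, one measured step bears on it, a 1.1-fold higher number from compound 2 to compound 3 (0.04 log units; within the scatter), a swap at that same place. Among the measured compounds shown here, no measured step brings in 4-methoxyphenyl there, so the guide is thin. No step beyond the scatter is expected in this assay, in either direction. The estimate means a 1.1-fold higher number from compound 3 to compound 4 (0.05 log units; within the scatter) as the expected step. The estimated value for compound 4 is 14000 nM, with an expected range from 6000 nM to 40000 nM in this assay.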

Compound 4, half-maximal inhibitory concentration: 30900 nM
The estimate for compound 4 lay 2.2-fold (0.34 log units) below the measured number; low and high end bracket the measured number.
By their numbers in this assay, from the lowest: compounds 2 and 3 (each within the scatter of the next); then compound 4. At a limit, above all of these: compound 1.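

In this assay this place, on a double-bonded chain carbon bound to a double-bonded ring carbon, now responds: 4-methoxyphenyl in place of 3-bromophenyl gives a 2.5-fold higher number from compound 3 to compound 4 (0.40 log units; beyond the scatter) and so moves beyond the scatter, which the earlier swap there did not. Methoxy in place of chloro on an aromatic carbon gives a 2.8-fold higher number from compound 2 to compound 4 (0.44 log units; beyond the scatter) as the matching step. Compound 4 still reads as a number and not as a limit, unlike one compound in the set: the limit of > 50000 nM in this assay, at which 1 of the 4 values shown sits.

Open, from the compounds shown here alone, is whether an amine or a carboxylic acid on that aromatic carbon would shift the number further. Also open, going by these compounds, is whether a longer chain such as ethoxy would follow methoxy.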